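Swapping an amide for a sulfone on the shared core

The compounds below may be only part of what the source reports. "The series", "measured", "known", "first", "only" and "open" are said of these compounds alone.

Of the compounds shown here, three built on one shared core have been tested in a functional assay on DU-145 cells (Homo sapiens) for inhibition, read by trypan blue exclusion, with a stated time of 72 h; on this read-out higher numbers stand for weaker inhibition and lower numbers for stronger inhibition. Compound 1 `Cn1c(=O)c(S(=O)(=O)c2ccc(F)cc2[N+](=O)[O-])cc2cnc(Nc3ccc4[nH]ccc4c3)nc21` carries a (4-fluoro-2-nitrophenyl)sulfonyl group and gives 1500 nM. Compound 2 `Cn1c(=O)c(C(=O)Nc2ccc(F)cc2)cc2cnc(Nc3ccc4[nH]ccc4c3)nc21` carries a (4-fluorophenyl)carbamoyl group instead and gives 5000 nM. Compound 3 `Cn1c(=O)c(C(=O)Nc2ccc(F)cc2F)cc2cnc(Nc3ccc4[nH]ccc4c3)nc21`, with a (2,4-difluorophenyl)carbamoyl group, gives 5000 nM; the step of no change at the digits printed from compound 2 to compound 3 (within the scatter) shows that the added fluoro left the number unchanged. Compound 3 thus stands level with compound 2, the two sharing the highest number, while compound 1 shows a lower number, a gap beyond the scatter.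

Compound 4 `COc1ccc(S(=O)(=O)c2cc3cnc(Nc4ccc5[nH]ccc5c4)nc3n(C)c2=O)cc1` differs from compound 3 by (4-methoxyphenyl)sulfonyl in place of (2,4-difluorophenyl)carbamoyl on an aromatic carbon. For the measured compounds named here, no measured step changes the linking group itself; the one step measured, from compound 2 to compound 3, only altered a fluoro and was flat. The values of compound 1 and compound 3 together hint that a sulfonyl bearer may give a lower number than a carbamoyl bearer. On that basis a step of a 2.5-fold lower number from compound 3 to compound 4 (0.40 log units; beyond the scatter) is expected. Compound 4 is therefore estimated at 2000 nM, between 700 nM and 6000 nM.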

Compound 4, half-maximal inhibitory concentration: 500 nM
Beside the measured number, compound 4's estimate is 4.0-fold (0.60 log units) above it, outside the stated range (below it).
By their numbers in this assay, from the lowest: compound 4; then compound 1; then compounds 2 and 3 (each within the scatter of the next).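

In this assay, swapping the carbamoyl groups at this position for (4-methoxyphenyl)sulfonyl gives a 10-fold lower number from compound 3 to compound 4 (1.00 log units; beyond the scatter) and a 10-fold lower number from compound 2 to compound 4 (1.00 log units; beyond the scatter) with no change to the shared core. The earlier compounds shown here also could not show that the group carried on the sulfonyl sulfur matters: 4-methoxyphenyl in place of 4-fluoro-2-nitrophenyl gives a 3.0-fold lower number from compound 1 to compound 4 (0.48 log units; beyond the scatter) and so moves the number beyond the scatter while the sulfonyl link stays. Nothing available here explains why these changes lower the number.

The compounds shown do not separate the contribution of the sulfonyl link from that of the methoxy group, as compound 4 differs from the carbamoyl compounds in both. As far as these compounds go, how the number would respond to an amine or a carboxylic acid on that aromatic ring in place of methoxy remains open.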